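The source may hold more compounds than are shown below. What is called first, only, known or untested is meant among the compounds shown, and "the series" means these compounds.

In an ADME assay on MT4 cells (Homo sapiens) for cytotoxicity, read by MTT assay (a lower number here means that less compound is tolerated, a higher number that more compound is tolerated), compound 1, `S=C(Nc1ccccc1)OCCc1ccccn1`, gives no number but only a limit, > 100000 nM. Compound 2, `Fc1ccc(NC(=S)OCCc2ccccn2)cc1`, likewise stops at a limit in this assay, > 100000 nM. Among the measured compounds shown here, the one measured step, a step that the two limits leave unreadable from compound 1 to compound 2, is therefore not readable, and the limit of > 100000 nM in this assay, at which 2 of the 2 values shown sit, is all that the two values show. Compound 3, `S=C(Nc1ccc(Cl)cc1)OCCc1ccccn1`, is compound 2 with chloro in place of fluoro on an aromatic carbon. For the measured compounds named here, no measured step bears directly on this exchange, since the two values of compound 1 and compound 2 both rest at the same limit and give no size for any change. Compound 3 is therefore expected to rest at that limit as well, and the step of a number no higher from compound 2 to compound 3 (the limit leaves the size open) is estimated to be none beyond the scatter. For compound 3 the value expected in this assay is 100000 nM, within a range from 50000 nM to 200000 nM.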

Compound 3, half-maximal cytotoxic concentration: 52000 nM
The estimate for compound 3 lay 1.9-fold (0.28 log units) above the measured number; the measured number falls inside the stated range.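

In this assay, chloro on this aromatic carbon, para to a large group, gives the first number rather than a limit among the three compounds. Measured against fluoro and against hydrogen at this position, the result is an at least 1.9-fold lower number from compound 2 to compound 3 (0.28 log units; that floor lies within the scatter) and an at least 1.9-fold lower number from compound 1 to compound 3 (0.28 log units; that floor lies within the scatter), so neither step is shown to go beyond the scatter. From the compounds shown here alone, the true size of both steps stays open, and the step between compound 1 and compound 2 still cannot be read, since those two compounds give only a limit: the limit of > 100000 nM in this assay, at which 2 of the 3 values shown sit.

The compounds shown leave open what bromo or methoxy on this same aromatic carbon would give in this assay. They also leave open whether chloro would give a similar number with a longer chain in the core.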